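Removing One Fluorine in Two Related Compound Pairs

This account rests on a few compounds, and the source may have more. Where it says the series, first, only, none or still open, it means among the compounds named here.

Compound 1 `CS(=O)(=O)c1ccc(Nc2ncc(F)c(Nc3nc4ccccc4s3)n2)cc1` and compound 2 `CS(=O)(=O)c1ccc(Nc2nccc(Nc3nc4ccccc4s3)n2)cc1` share a core and differ by a single change, (hydrogen in place of fluoro on an aromatic carbon). In a functional assay on MCF7 cells (Homo sapiens) for antiproliferative activity, read by MTT assay, with a stated time of 48 h (on this read-out higher numbers stand for weaker inhibition and lower numbers for stronger inhibition), compound 1 gives 6880 nM. Compound 2 gives 10600 nM in this assay, and the step between them is a 1.5-fold higher number from compound 1 to compound 2 (0.19 log units; within the scatter). Compound 3 `COc1ccc2nc(Nc3nc(Nc4ccc(S(N)(=O)=O)cc4)ncc3F)sc2c1` has a different core; the difference between the two cores is not broken down here. In this assay compound 3 reaches only the limit of > 50000 nM, which is not a number. Compound 4 `COc1ccc2nc(Nc3ccnc(Nc4ccc(S(N)(=O)=O)cc4)n3)sc2c1` is not yet measured and differs from compound 3 by the same change, (hydrogen in place of fluoro on an aromatic carbon). Resting on the measured step of a 1.5-fold higher number from compound 1 to compound 2 (0.19 log units; within the scatter), the step from compound 3 to compound 4 is expected to be a step that the limit leaves unreadable from compound 3 to compound 4. Compound 4 is therefore estimated at 65000 nM, with a real chance that this assay again reports only a limit, given (the limit of > 50000 nM in this assay, at which 1 of the 3 values shown sits).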

Compound 4, half-maximal inhibitory concentration: 11000 nM
The estimate for compound 4 lay 5.9-fold (0.77 log units) above the measured number, and the stated range ends above it.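

In this assay, putting hydrogen in place of fluoro gives an at least 4.5-fold lower number from compound 3 to compound 4 (0.65 log units; beyond the scatter). Compound 3 gives > 50000 nM, which is a limit and not a number, so this step has a minimum size but no exact one. The change therefore does not carry over between these two cores with the same size, though two pairs give no rule for other cores and do not show the reason for the gap: the same change on two cores in this assay, a 1.5-fold higher number (0.19 log units; within the scatter) from compound 1 to compound 2 and an at least 4.5-fold lower number (0.65 log units; beyond the scatter) from compound 3 to compound 4, at least 7.0-fold (0.84 log units) apart, beyond the scatter of two such steps

The compounds shown leave open which part of the difference between the two cores goes with this gap. They also leave open how chloro or an amine at the same place would behave on either core.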